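The source may hold more compounds than are shown below. What is called first, only, known or untested is meant among the compounds shown, and "the series" means these compounds.

Compound 1 `COc1ccc2cc([C@H](C)c3nnc(SCc4ccc(Cl)cc4)n3-c3ccc(F)cc3)ccc2c1`: > 400000 nM, a limit of the assay
Compound 2 `COc1ccc2cc([C@H](C)c3n[nH]c(=S)n3-c3cccc(Cl)c3)ccc2c1`: "not determined" (no result reported)
Compound 3 `COc1ccc2cc([C@H](C)c3nnc(SCc4ccc(Cl)cc4)n3-c3ccc(Cl)cc3)ccc2c1`: 110000 nM

Among the measured compounds shown here, in a functional assay on LNCaP cells (Homo sapiens) for cytotoxicity, read by MTT assay (a lower number here means a stronger inhibitor, a higher number a weaker inhibitor), compound 3 gives the only actual number, 110000 nM, so there is no second number to rank it against. The entry for compound 1 is a limit, as noted in the limit of > 400000 nM in this assay, at which 1 of the 3 values shown sits. Compound 2 has no result.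

Compound 4 `COc1ccc2cc([C@H](C)c3nnc(SCc4ccccc4)n3-c3ccc(Cl)cc3)ccc2c1` differs from compound 3 by hydrogen in place of chloro on an aromatic carbon, para to a large group, which turns 4-chlorobenzyl into benzyl.

For the measured compounds named here, one measured step bears on this, and only indirectly: an at least 3.6-fold lower number from compound 1 to compound 3 (0.56 log units; beyond the scatter). It is chloro in place of fluoro on an aromatic carbon of a different ring, and it starts from a limit, so its true size is open. Going by the values given here, it shows that a halogen swap can move the number in this assay beyond the scatter, but no measured step removes a halogen from the benzyl group. A small move toward a higher number is therefore expected, probably not clearly beyond the scatter. The expected step is a 1.6-fold higher number from compound 3 to compound 4 (0.21 log units; within the scatter). For compound 4 the estimated value is 180000 nM, with an expected range of 60000 nM to 400000 nM.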

Compound 4, half-maximal inhibitory concentration: 50400 nM
For compound 4 the middle estimate is 3.6-fold (0.55 log units) above the measured one; measured number below the stated range.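

In this assay, among the compounds shown here, the change from 4-chlorobenzyl to benzyl gives a 2.2-fold lower number from compound 3 to compound 4 (0.34 log units; beyond the scatter), the first measured step at this position para to a large group. The chloro there is therefore not required for activity in this assay, and the compound without it has the lower number. Together with an at least 3.6-fold lower number from compound 1 to compound 3 (0.56 log units; beyond the scatter), which lies on a different ring and starts from a limit, this shows that changing a single halogen at either of two places can move the number beyond the scatter, and here removing the halogen lowers it.

Only chloro and hydrogen are shown at this position, so it remains open whether a fluoro, a methoxy, an amine or a carboxylic acid there would continue this trend or reverse it. Compound 1 gives a limit rather than a number, which leaves the true size of the halogen step on the other ring open: the limit of > 400000 nM in this assay, at which 1 of the 4 values shown sits.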